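The compounds below may be only part of what the source reports. "The series", "measured", "known", "first", "only" and "open" are said of these compounds alone.

Of the compounds shown here, three have been measured in a functional assay on VCaP cells (Homo sapiens) for antiproliferative activity, read by propidium iodide staining, with a stated time of 96 h; a lower number here means a stronger inhibitor, a higher number a weaker inhibitor. Compound 1 `CC(O)(CSc1cccc(S(F)(F)(F)(F)F)c1)C(=O)Nc1ccc(C#N)c(C(F)(F)F)c1` gives 31700 nM in this assay. Compound 2 `CC(O)(CSc1cccc(S(F)(F)(F)(F)F)c1)C(=O)Nc1ccc([N+](=O)[O-])c(C(F)(F)F)c1` differs from compound 1 in one place, (nitro in place of cyano on an aromatic carbon), and in this assay compound 2 gives 9800 nM. That single change made a 3.2-fold lower number from compound 1 to compound 2 (0.51 log units; beyond the scatter). Compound 3 `CC1(C)C(=O)N(c2ccc(C#N)cc2C(F)(F)F)C(=S)N1c1cccc(S(F)(F)(F)(F)F)c1` is built on a different core; the difference between the two cores is not broken down here. In this assay compound 3 gives 100000 nM, the highest number among the three measured compounds.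

Compound 4 `CC1(C)C(=O)N(c2ccc([N+](=O)[O-])cc2C(F)(F)F)C(=S)N1c1cccc(S(F)(F)(F)(F)F)c1` has not yet been measured. It shares the core of compound 3 and differs from it in one place, (nitro in place of cyano on an aromatic carbon). Within the data shown here, this is the same kind of change as the one from compound 1 to compound 2, but not the same: in compound 1 the group being replaced sits ortho to a trifluoromethyl group, whereas in compound 3 it sits meta to a trifluoromethyl group, in both cases para to a large group. Among the measured compounds shown here, because the one earlier example of this change gave a 3.2-fold lower number from compound 1 to compound 2 (0.51 log units; beyond the scatter), a step of similar size and direction is expected here, a 2.9-fold lower number from compound 3 to compound 4 (0.46 log units; beyond the scatter). This rests on a single pair on a different core, so the range is kept wide, and the very high number of compound 3 leaves room for compound 4 to stay weak. Compound 4 is estimated to give 35000 nM in this assay, somewhere from 12000 nM to 100000 nM.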

Compound 4, half-maximal inhibitory concentration: 100000 nM
For compound 4 the middle estimate is 2.9-fold (0.46 log units) below the measured one; measured number inside the range.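

In this assay, putting nitro in place of cyano on the core of compound 3 gives no change at the digits printed from compound 3 to compound 4 (within the scatter), while the same exchange on the core of compound 1 gives a 3.2-fold lower number from compound 1 to compound 2 (0.51 log units; beyond the scatter). The exchange therefore does not behave alike on the two cores, and the gap between the two steps is larger than repeat measurements alone would be expected to produce: the same change on two cores in this assay, a 3.2-fold lower number (0.51 log units; beyond the scatter) from compound 1 to compound 2 and no change at the digits printed (within the scatter) from compound 3 to compound 4, 3.2-fold (0.51 log units) apart, beyond the scatter of two such steps

Among these compounds, this shows that, in this series, a gain seen on one core cannot simply be assumed on the other, but with only one pair per core it does not show why the two steps part ways, whether through the cores themselves or through the different placing of the trifluoromethyl group relative to the exchanged group.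

The compounds shown leave open how other groups in this place, such as a chlorine atom or a carboxylic acid, would behave on either core. They also leave open whether the nitro for cyano exchange would lower the number on a third core, or whether the result on the core of compound 1 stands alone.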